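Propyl in place of methylsulfonyl on the saturated chain

The compounds below may be only part of what the source reports. "The series", "measured", "known", "first", "only" and "open" are said of these compounds alone.

Measured so far:
compound 1, `Cn1c(-c2ccccc2C(F)(F)F)nnc1C12CCC(CCS(C)(=O)=O)(CC1)CC2`: > 4000 nM
compound 2, `CC(O)CCCC12CCC(c3nnc(-c4ccccc4C(F)(F)F)n3C)(CC1)CC2`: > 1000 nM

In an assay on CHO-K1 cells for inhibition of 11-beta-hydroxysteroid dehydrogenase type 2 (Homo sapiens), read by scintillation proximity assay (on this read-out lower numbers stand for stronger inhibition and higher numbers for weaker inhibition), compound 1 gives only a limit, > 4000 nM. Compound 2 likewise gives only a limit in this assay, > 1000 nM. The step that the two limits leave unreadable from compound 1 to compound 2 is therefore not readable, since both ends sit at limits (the limit of > 4000 nM in this assay, at which 1 of the 2 values shown sits, and (the limit of > 1000 nM in this assay, at which 1 of the 2 values shown sits)). Compound 1 thus stands at a limit and nowhere else on the numbers shown.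

Compound 3, `CCCCCC12CCC(c3nnc(-c4ccccc4C(F)(F)F)n3C)(CC1)CC2`, differs from compound 1 by propyl in place of methylsulfonyl on a saturated chain carbon, two bonds along the chain from a saturated ring carbon. Going by the values given here, the only measured step at this chain position is the unreadable one, so nothing measured here fixes a size or a direction for the change. The step that the limit leaves unreadable from compound 1 to compound 3 is accordingly expected to be small, within the scatter. Compound 3 is expected to give about 5000 nM in this assay, somewhere between 800 nM and 30000 nM, and quite possibly again only as a limit.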

Compound 3, half-maximal inhibitory concentration: 1300 nM
Compound 3: the middle estimate sits 3.8-fold (0.59 log units) above what was measured; low and high end bracket the measured number.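

In this assay, the change at this position now has a direction: propyl in place of methylsulfonyl gives an at least 3.0-fold lower number from compound 1 to compound 3 (0.48 log units; beyond the scatter). That size is only a lower bound on the step, and the true gap may be wider: the limit of > 4000 nM in this assay, at which 1 of the 3 values shown sits. Compound 3 is the only one of the three shown with a number rather than a limit, and the steps that touch compound 2 cannot be read.

The compounds shown leave open whether the lower number goes with the loss of methylsulfonyl or with propyl itself, and how far it would carry to other groups here. A longer chain, a carboxylic acid or an amine on a saturated chain carbon, two bonds along the chain from a saturated ring carbon, would address both points.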